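This account rests on a few compounds, and the source may have more. Where it says the series, first, only, none or still open, it means among the compounds named here.

The measured compounds:
In a functional assay on Bel-7402 cells (Homo sapiens) for antiproliferative activity, read by MTT assay, with a stated time of 48 h (a lower number here means a stronger inhibitor of growth, a higher number a weaker inhibitor of growth), compound 1 `COc1cc2c(cc1O)C(=O)/C(=C/c1cc(OC)c(OC)c(OC)c1)C2` gives > 10000 nM, a limit of the assay rather than a number.
Compound 2 `COc1cc2c(cc1O)C(=O)/C(=C/c1ccc(OC)c(OC)c1OC)C2` gives 9650 nM in this assay.
Compound 3 `COc1cc2c(cc1OC)C(=O)/C(=C/c1cc(OC)c(OC)c(OC)c1)C2` gives > 10000 nM, again a limit and not a number.

Compounds 1 and 2 are built of the same atoms joined differently; the difference between the two cores is not broken down here. Compound 3 differs from compound 1 by methyl in place of hydrogen on an oxygen on an aromatic ring, and the step this made, a step that the two limits leave unreadable from compound 1 to compound 3, cannot be read because of the limit of > 10000 nM in this assay, at which 2 of the 3 values shown sit. Compound 4 `COc1cc2c(cc1OC)C(=O)/C(=C/c1ccc(OC)c(OC)c1OC)C2` is the unmeasured partner of compound 2 and differs from it by methyl in place of hydrogen on an oxygen on an aromatic ring, the same change at the same place. The step expected from it, a 1.2-fold higher number from compound 2 to compound 4 (0.09 log units; within the scatter), is estimated to be small, resting on the unreadable earlier step and on compound 2 standing at 9650 nM. Compound 4 is therefore expected to give about 12000 nM, between 5000 nM and 30000 nM.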

Compound 4, concentration for 50% growth inhibition: > 10000 nM
Compound 4 was reported as a limit; the forecaster's own chance of this, stated with the estimate: 60%; the middle value does not contradict the limit.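

In this assay, hydroxy to methoxy on the core of compound 2 gives an at least 1.0-fold higher number from compound 2 to compound 4 (0.01 log units; that floor lies within the scatter) for this step. On these data alone, compound 4 gives > 10000 nM here, a limit of the assay and not a number, so the true size of the step is unknown. The same change on the core of compound 1 also ends at a limit, and neither step can be read closely enough to show whether the change carries the same size from one core to the other: (the limit of > 10000 nM in this assay, at which 3 of the 4 values shown sit).

The compounds shown leave open whether an amine or a carboxylic acid in place of the hydroxy on the aromatic ring would give a readable number on either core.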